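The source may hold more compounds than are shown below. What is called first, only, known or untested is meant among the compounds shown, and "the series" means these compounds.

Of the compounds shown here, three sharing one core have been tested in a functional assay on HCT-116 cells (Homo sapiens) for inhibition, read by sulforhodamine B assay, with a stated time of 48 h, tested at 50 uM; on this read-out lower numbers stand for less inhibition of growth and higher numbers for more inhibition of growth at the one concentration tested. Compound 1 `COc1cc(/C=C/C(=O)/C=C/c2ccccc2)ccc1OCc1cn(CCCOc2cc(=O)oc3ccccc23)nn1` gives 45%. Compound 2 `COc1ccccc1/C=C/C(=O)/C=C/c1ccc(OCc2cn(CCCOc3cc(=O)oc4ccccc34)nn2)c(OC)c1` gives 53%. Compound 3 `COc1ccccc1/C=C/C(=O)/C=C/c1ccc(OCc2cn(CCCCOc3cc(=O)oc4ccccc34)nn2)c(OC)c1` gives 43%. Within the data shown here, the one step between compounds that differ in a single place, a number 8 percentage points higher from compound 1 to compound 2 (within the scatter), lies within the scatter. Compound 3 stands at the low end of the three numbers, yet its gaps to compound 1 and to compound 2 are both within the scatter, so none of the three can be told apart with confidence.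

Compound 4 `COc1cc(/C=C/C(=O)/C=C/c2cccc3ccccc23)ccc1OCc1cn(CCCCOc2cc(=O)oc3ccccc23)nn1` differs from compound 3 by naphthalen-1-yl in place of 2-methoxyphenyl on a double-bonded chain carbon bound to a double-bonded chain carbon. Among the measured compounds shown here, no measured step exchanges one aromatic ring for another, and the only step available, the change from compound 1 to compound 2, stayed within the scatter. There is therefore no basis for expecting a step beyond the scatter in this assay in either direction. Compound 4 is expected to give 45%, with a range from 28% to 62%. The expected step is a number 2 percentage points higher from compound 3 to compound 4 (within the scatter).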

Compound 4, percent growth inhibition at one concentration: 56%
The estimate for compound 4 lay 11 percentage points below the measured number; measured number inside the range.
By their numbers in this assay, from the lowest: compounds 3, 1, 2 and 4 (each within the scatter of the next, the first and the last beyond it).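

In this assay, among these compounds, exchanging 2-methoxyphenyl for naphthalen-1-yl on a double-bonded chain carbon bound to a double-bonded chain carbon gives a number 13 percentage points higher from compound 3 to compound 4 (beyond the scatter), so a modest change in the read-out can be seen for the first time in this set. The earlier step at the same end of the molecule, a number 8 percentage points higher from compound 1 to compound 2 (within the scatter), could not be read as a real difference, whereas replacing the whole aromatic group here can. Nothing shown explains this step, and the exchange both removes the methoxy oxygen and adds a second aromatic ring, so the data cannot separate those two parts of the change.

As far as these compounds go, whether the higher number belongs to naphthalen-1-yl in particular remains open. It is also unknown how an amine or a carboxylic acid on the aromatic ring at this place would read.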